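The source may report more compounds than this note shows. Statements on the series, on what has been measured and on what is new or still open speak of the compounds shown alone.

Measured compounds:
Compound 1 `CC(C)C(=O)N1CCCn2nc(COc3ccccc3)cc21` – 59%
Compound 2 `O=C(c1ccccc1)N1CCCn2nc(COc3ccccc3)cc21` – 63%

In a functional assay on HEK293 cells for positive allosteric modulation of metabotropic glutamate receptor 5 (Homo sapiens), read by calcium flux (on this read-out lower numbers stand for smaller maximal responses and higher numbers for larger maximal responses), compound 2 gives 63%, the highest of the two numbers recorded; the nearest is compound 1 with 59%, and the two lie within the scatter of each other, so no order between them is claimed. Among the measured compounds shown here, the single measured step, a number 4 percentage points higher from compound 1 to compound 2 (within the scatter), exchanges the group on the carbonyl carbon and stays within the scatter.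

Compound 3 `O=C(c1ccc(Cl)cc1)N1CCCn2nc(COc3ccccc3)cc21` is the next member. Its difference from compound 2 is chloro in place of hydrogen on an aromatic carbon: the change sits on the aromatic ring of the carbonyl substituent, leaving the rest of the shared core untouched. For the measured compounds named here, no measured step alters this ring; the only step to hand, from isopropyl to phenyl on the carbonyl carbon, touches a different part of the molecule and moved the maximal response by an amount within the scatter. There is thus no measured basis for expecting a shift beyond the scatter in this assay, in either direction, and the estimate for compound 3 is set close to compound 2, with a range wide enough to cover the usual scatter.

Expected for compound 3: 63% (range 48% to 78%), a step of no change at the digits printed from compound 2 to compound 3 (within the scatter).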

Compound 3, largest response reached (reported as percent of maximum), in percent of the reference or control that the assay uses: 68%
Beside the measured number, compound 3's estimate is 5 percentage points below it; measured number inside the range.
By their numbers in this assay, from the lowest: compounds 1, 2 and 3 (each within the scatter of the next).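

In this assay, chloro in place of hydrogen on an aromatic carbon of the six-membered aromatic ring, para to a large group, gives a number 5 percentage points higher from compound 2 to compound 3 (within the scatter), so this ring position, untouched by the earlier step, takes a chlorine with no shift that can be told from the scatter. Read against the isopropyl amide, the 4-chlorophenyl group gives a number 9 percentage points higher from compound 1 to compound 3 (within the scatter), and isopropyl, phenyl and 4-chlorophenyl on the carbonyl carbon therefore remain unseparated on this read-out, with no order among compounds 1, 2 and 3 claimed. Nothing at hand bears on what lies behind these small differences.

Still open, as far as these compounds go, is whether a methoxy, a nitrile or a dimethylamino group in place of the chloro, or a cyclohexyl or pyridyl group on the carbonyl carbon, would move the maximal response beyond the scatter in either direction. All three compounds share the rest of the core, so they say nothing about how the read-out answers to changes there, for instance a carboxylic acid or a longer chain in place of the phenoxymethyl group.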